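Swapping the amide substituent in a cytotoxicity series

This account rests on a few compounds, and the source may have more. Where it says the series, first, only, none or still open, it means among the compounds named here.

Three compounds built on the shared core of compound 1, `CCn1c(C(=O)NCCCN(C)C)ccc1C(CC)(CC)c1ccc(OCC(=O)C(C)(C)C)c(C)c1`, have been tested in an ADME assay on L02 cells (Homo sapiens) for cytotoxicity, read by MTT assay, with a stated time of 48 h; on this read-out higher numbers stand for weaker inhibition and lower numbers for stronger inhibition. Compound 1 gives 670 nM. Compound 2, `CCn1c(C(=O)NCCN)ccc1C(CC)(CC)c1ccc(OCC(=O)C(C)(C)C)c(C)c1`, gives 2500 nM. Compound 3, `C#CCNC(=O)c1ccc(C(CC)(CC)c2ccc(OCC(O)C(C)(C)C)c(C)c2)n1CC`, gives 4400 nM. Compound 3 sits beyond the scatter above compound 1, while compound 2 lies within the scatter of compound 3, so no order between those two can be read.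

Compound 4, `CCn1c(C(=O)N(C)CC(=O)O)ccc1C(CC)(CC)c1ccc(OCC(O)C(C)(C)C)c(C)c1`, differs from compound 3 by (carboxymethyl)(methyl)amino in place of propargylamino on a carbonyl carbon.

Among the measured compounds shown here, only one measured step changes the group attached to the amide nitrogen: a 3.7-fold higher number from compound 1 to compound 2 (0.57 log units; beyond the scatter). That step is modest, and the new change in compound 4 is a different one, so it gives only a rough guide. The expectation is therefore a small shift in compound 4, upward if anything, with a 1.4-fold higher number from compound 3 to compound 4 (0.13 log units; within the scatter) likely near the scatter. Compound 4 is estimated at 6000 nM, within a range from 2500 nM to 15000 nM.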

Compound 4, half-maximal inhibitory concentration: 32600 nM
Compound 4: the middle estimate sits 5.4-fold (0.74 log units) below what was measured; the measured number lies above the stated range.
By their numbers in this assay, from the lowest: compound 1; then compounds 2 and 3 (each within the scatter of the next); then compound 4.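

In this assay, the group on the carbonyl carbon proves able to move the number beyond the scatter: putting (carboxymethyl)(methyl)amino in place of propargylamino gives a 7.4-fold higher number from compound 3 to compound 4 (0.87 log units; beyond the scatter) on this read-out. The earlier step, a 3.7-fold higher number from compound 1 to compound 2 (0.57 log units; beyond the scatter), altered only a chain ending in an amine, whereas this one replaces the whole group on the carbonyl carbon, and the incoming group ends in a carboxylic acid. Nothing measured here explains the shift.

The new group differs from propargylamino in more than one way, so the methyl on the amide nitrogen and the carboxymethyl chain cannot yet be told apart. A plain carboxymethylamino group, without the methyl, or a methyl ester in place of the carboxylic acid, would help show which part goes with the higher number.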